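A few compounds are considered here, and "the series" means these few. Any claim that something is new, unique, unknown or untested is made for them only; others in the source may bear on it.

Compound 1, `COc1cc(-n2ncnc2-c2ccc(F)cc2)cc(OC)c1OC`, gives > 10000 nM.
Compound 2, `COc1cc(-c2ncnn2-c2cccc([N+](=O)[O-])c2)cc(OC)c1OC`, gives > 10000 nM.

In a functional assay on Jurkat cells (Homo sapiens) for antiproliferative activity, read by MTT assay, with a stated time of 72 h (a higher number here means a weaker inhibitor, a lower number a stronger inhibitor), compound 1 reaches only a limit, not a number. Compound 2 likewise stands at a limit in this assay. Both values sit at the limit of > 10000 nM in this assay, at which 2 of the 2 values shown sit, so compound 1 stands at the weak end of what can be told here. Compound 3, `CCOc1ccc(-c2ncnn2-c2cc(OC)c(OC)c(OC)c2)cc1`, is not yet measured; it differs from compound 1 by ethoxy in place of fluoro on an aromatic carbon. For the measured compounds named here, with no measured step to lean on, the expected step of a number no higher from compound 1 to compound 3 (the limit leaves the size open) is none beyond the scatter. Compound 3 is expected at 10000 nM, between 2000 nM and 50000 nM.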

Compound 3, half-maximal inhibitory concentration: 5 nM
Compound 3: middle estimate off by 2000-fold (3.30 log units), on the high side; the whole stated range lies above it.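

In this assay, for the compounds shown here, the earlier compounds gave only limits and so said nothing about this position. The change of fluoro to ethoxy, on an aromatic carbon para to a large group, now shows that this place can govern activity: an at least 2000-fold lower number from compound 1 to compound 3 (3.30 log units; beyond the scatter). Going by these compounds, compound 1 stands at a limit, so the true size of the step remains open: the limit of > 10000 nM in this assay, at which 2 of the 3 values shown sit.

The compounds shown do not tell whether the oxygen or the ethyl part of ethoxy matters. On these data alone, how a methoxy group, a longer chain or an amine would behave at this place also remains open.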